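Methyl on the aromatic ring of a spiro-oxindole chromone

The source may hold more compounds than are shown below. What is called first, only, known or untested is meant among the compounds shown, and "the series" means these compounds.

Compound 1 `Cc1ccc2c(c1)C1(C(=O)N2C)C(C#N)=C(N)Oc2cc3oc(-c4ccccc4)cc(=O)c3c(O)c21`: 5870 nM
Compound 2 `N#CC1=C(N)Oc2cc3oc(-c4ccccc4)cc(=O)c3c(O)c2C12C(=O)Nc1ccccc12`: 36400 nM

Of the compounds shown here, two have been measured in a functional assay on K562 cells (Homo sapiens) for antiproliferative activity, read by MTT assay, with a stated time of 48 h; a higher number here means a weaker inhibitor, a lower number a stronger inhibitor. Compound 2 gives 36400 nM, the higher of the two numbers, and compound 1 gives 5870 nM, a lower number that lies beyond the usual scatter. For the measured compounds named here, no single-change pair stands between them, since compound 1 carries two changes relative to compound 2.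

Compound 3 `Cc1ccc2c(c1)C1(C(=O)N2)C(C#N)=C(N)Oc2cc3oc(-c4ccccc4)cc(=O)c3c(O)c21` differs from compound 2 by one of these: methyl in place of hydrogen on an aromatic carbon. Compound 1, which holds this methyl together with a methyl on the lactam nitrogen, shows a lower number than compound 2, so the aromatic methyl alone is expected to bring a modest step downward, a step that may sit near the edge of the scatter: a 2.4-fold lower number from compound 2 to compound 3 (0.39 log units; beyond the scatter). On that basis compound 3 is estimated at 15000 nM, with a range from 5000 nM to 40000 nM.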

Compound 3, half-maximal inhibitory concentration: > 50000 nM
Compound 3 was reported as a limit; the forecaster's own chance of this, stated with the estimate: 3%; middle value at least 3.3-fold (0.52 log units) from the limit.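

Compound 3 stands at a limit in this assay, not at a number: the limit of > 50000 nM in this assay, at which 1 of the 3 values shown sits. Methyl in place of hydrogen on an aromatic carbon, taken alone, therefore shows no lower number, and the step reads an at least 1.3-fold higher number from compound 2 to compound 3 (0.13 log units; that floor lies within the scatter), so compound 3 cannot be ordered against compound 2. The two methyls of compound 1, which could not be told apart before, now separate: hydrogen in place of methyl on an amide-type nitrogen in a ring gives an at least 8.5-fold higher number from compound 1 to compound 3 (0.93 log units; beyond the scatter), so with the aromatic methyl in place, the lower number of compound 1 goes with the nitrogen methyl.

As far as these compounds go, whether the nitrogen methyl would do the same on a ring with hydrogen at that aromatic carbon stays open. Also open, from the compounds shown here alone, is how an ethyl chain on that nitrogen, or a methoxy group or chlorine on the aromatic carbon, would read.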